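A few compounds are considered here, and "the series" means these few. Any claim that something is new, unique, unknown or untested is made for them only; others in the source may bear on it.

Working notes on the series. Compound 1 `CCOc1ccccc1-n1nncc1CN1C(=O)C2(C(C#N)=C(N)Oc3c2c2nc4ccccc4nc2c2ccccc32)c2ccccc21` is the reference point. In a functional assay on A549 cells (Homo sapiens) for antiproliferative activity, read by MTT assay, with a stated time of 48 h (a lower number here means a stronger inhibitor, a higher number a weaker inhibitor), compound 1 reaches only the limit of the assay, > 50000 nM. Compound 2 `N#CC1=C(N)Oc2c(c3nc4ccccc4nc3c3ccccc23)C12C(=O)N(Cc1cnnn1-c1ccc(F)c(Cl)c1)c1ccccc12` carries 3-chloro-4-fluorophenyl in place of 2-ethoxyphenyl on the aromatic nitrogen. In this assay compound 2 likewise stops at the limit, > 50000 nM. The step that the two limits leave unreadable from compound 1 to compound 2 is therefore unreadable. Compound 3 `N#CC1=C(N)Oc2c(N)cc3nc4ccccc4nc3c2C12C(=O)N(Cc1cnnn1-c1ccc(Cl)cc1)c1ccccc12` is the starting point for the step followed here. In this assay compound 3 gives only the limit, > 50000 nM. Where compound 3 stands: no number, only a limit, and the two other values shown are limits as well, since (the limit of > 50000 nM in this assay, at which 3 of the 3 values shown sit). Compound 4 `CC(=O)Nc1ccc(-n2nncc2CN2C(=O)C3(C(C#N)=C(N)Oc4c(N)cc5nc6ccccc6nc5c43)c3ccccc32)cc1` is not yet measured; its difference from compound 3 is acetamido in place of chloro on an aromatic carbon. No measured step bears on this change; the single step shown, at the aromatic-nitrogen substituent, is itself unreadable. Compound 4 is therefore expected to remain around the limit in this assay, with an estimated 50000 nM between 15000 nM and 150000 nM. The step of a number no higher from compound 3 to compound 4 (the limit leaves the size open) is accordingly estimated as nothing readable.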

Compound 4, half-maximal inhibitory concentration: > 50000 nM
Compound 4 ended at the assay's limit; the forecaster's own chance of this, stated with the estimate: 80%; the middle value lies on the limit itself.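

Among these compounds, compound 3 and compound 4 each give only a limit in this assay, so no step between them can be read: the limit of > 50000 nM in this assay, at which 4 of the 4 values shown sit. The compounds shown leave open which structural change, if any, would bring a value inside the readable range of this assay.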